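The compounds below may be only part of what the source reports. "The series", "measured", "known", "first", "only" and "open" are said of these compounds alone.

Measured compounds:
- compound 1 `CCn1c(C(=O)NCCN(C)C)ccc1C(CC)(CC)c1ccc(OCC(O)C(C)(C)C)c(C)c1`: 1630 nM
- compound 2 `C#CCNC(=O)c1ccc(C(CC)(CC)c2ccc(OCC(O)C(C)(C)C)c(C)c2)n1CC`: 16200 nM
- compound 3 `CCn1c(C(=O)NCC(OC)OC)ccc1C(CC)(CC)c1ccc(OCC(O)C(C)(C)C)c(C)c1`: 14600 nM

The three compounds were tested in a functional assay on PC-3 cells (Homo sapiens), read by MTT assay, with a stated time of 48 h; a lower number here means a stronger inhibitor, a higher number a weaker inhibitor. Compound 1 stands lowest of the three numbers; compound 3 gives 14600 nM and compound 2 gives 16200 nM, both well beyond the scatter from compound 1.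

The unmeasured compound 4 `CCn1c(C(=O)OCc2ccc(F)cc2)ccc1C(CC)(CC)c1ccc(OCC(O)C(C)(C)C)c(C)c1` differs from compound 1 in one place: (4-fluorobenzyl)oxy in place of (2-(dimethylamino)ethyl)amino on a carbonyl carbon. The step to compound 4 removes the whole (2-(dimethylamino)ethyl)amino group, and the two measured steps that bear on it each altered the chain inside that same group. Those steps were a 9.9-fold higher number from compound 1 to compound 2 (1.00 log units; beyond the scatter) and a 9.0-fold higher number from compound 1 to compound 3 (0.95 log units; beyond the scatter), and between the two products the difference was only a 1.1-fold lower number from compound 2 to compound 3 (0.05 log units; within the scatter). Both times the number rose by about the same amount once the (dimethylamino)methyl portion was gone, whatever took its place. Compound 4 removes that portion too, together with the amide-type nitrogen, so a rise in this assay of similar or somewhat larger size is expected, not a fall.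

Compound 4 is therefore estimated at 16000 nM, with a likely range from 5000 nM to 50000 nM, which is expected to correspond to a 9.8-fold higher number from compound 1 to compound 4 (0.99 log units; beyond the scatter).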

Compound 4, half-maximal inhibitory concentration: > 50000 nM
Compound 4 was reported as a limit (the forecaster's own chance of this, stated with the estimate: 10%); middle value at least 3.1-fold (0.49 log units) from the limit.
By their numbers in this assay, from the lowest: compound 1; then compounds 3 and 2 (each within the scatter of the next). At a limit, above all of these: compound 4.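

In this assay compound 4 is reported only as a limit of the assay, not as a number: the limit of > 50000 nM in this assay, at which 1 of the 4 values shown sits.

Replacing the whole (2-(dimethylamino)ethyl)amino group with (4-fluorobenzyl)oxy on the carbonyl carbon gives an at least 30-fold higher number from compound 1 to compound 4 (1.48 log units; beyond the scatter), and the result also stands apart from the two compounds that had already lost the (dimethylamino)methyl portion, with an at least 3.4-fold higher number from compound 3 to compound 4 (0.53 log units; beyond the scatter) and an at least 3.0-fold higher number from compound 2 to compound 4 (0.48 log units; beyond the scatter). Within the data shown here, the earlier compounds changed only the far end of the chain and kept the amide-type nitrogen, so this is the first sign that the number can climb further once that nitrogen is gone as well.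

The nitrogen leaves and the (4-fluorobenzyl)oxy group with its aromatic ring enters in a single step, so the compounds shown cannot separate the two changes; an amide carrying the same 4-fluorobenzyl group, or a carboxylic acid at this carbonyl carbon, would speak to that. From the compounds shown here alone, it also stays open whether a longer chain ending in the same dimethylamino group, or a ring amine such as morpholine, would hold the number of compound 1 or lower it.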